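A few compounds are considered here, and "the series" means these few. Any claim that something is new, unique, unknown or untested is made for them only; others in the source may bear on it.

Compound 2 `COC(=O)c1cc(-c2cccc(NC(=O)c3ccc(/C=C/C(=O)c4ccc(OC)cc4)cc3)c2)on1`, compound 1 `COC(=O)c1cc(-c2cccc(NC(=O)c3ccc(/C=C/C(=O)c4cccc(Cl)c4)cc3)c2)on1` and compound 3 `COC(=O)c1cc(-c2cccc(NC(=O)c3ccc(/C=C/C(=O)c4ccc(Cl)cc4)cc3)c2)on1` share one core and differ only in the aryl group that sits on a carbonyl carbon. In an ADME assay on Vero cells (Chlorocebus sabaeus) for cytotoxicity, read by MTT assay, with a stated time of 72 h (on this read-out higher numbers stand for lower toxicity in this test and lower numbers for higher toxicity in this test), compound 2 gives > 10 ug/mL, which is a limit of the assay and not a number. Compound 1 likewise gives only a limit, > 2.5 ug/mL. Compound 3 also gives only a limit, > 50 ug/mL. The steps a step that the two limits leave unreadable from compound 1 to compound 2, a step that the two limits leave unreadable from compound 1 to compound 3 and a step that the two limits leave unreadable from compound 2 to compound 3 cannot be read in size because of the limit of > 10 ug/mL in this assay, at which 1 of the 3 values shown sits, the limit of > 2.5 ug/mL in this assay, at which 1 of the 3 values shown sits, and the limit of > 50 ug/mL in this assay, at which 1 of the 3 values shown sits, are all limits rather than numbers. Compound 4 `COC(=O)c1cc(-c2cccc(NC(=O)c3ccc(/C=C/C(=O)c4ccccc4C)cc3)c2)on1` has not yet been measured; its change from compound 2 is 2-methylphenyl in place of 4-methoxyphenyl on a carbonyl carbon. Among the compounds with values here, since none of the measured steps has a readable size, no step beyond the scatter is expected in either direction, and a limit rather than a number is likely once more. Compound 4 is expected to give about 30 ug/mL in this assay, within 5 ug/mL to 100 ug/mL, which means an expected step that the limit leaves unreadable from compound 2 to compound 4.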

Compound 4, half-maximal cytotoxic concentration: > 25 ug/mL
Compound 4 ended at the assay's limit (the forecaster's own chance of this, stated with the estimate: 80%); the middle value lies beyond the limit too.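

Compound 4, like compound 1, compound 2 and compound 3, gives only a limit of the assay and not a number, so the steps from each of them to compound 4 cannot be read in size. The compounds shown leave open whether the aryl group on the carbonyl carbon changes the result in this assay at all.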